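A triazole takes the place of a pyrazole

The compounds below may be only part of what the source reports. "The series", "measured", "known", "first", "only" and "open" are said of these compounds alone.

In a physicochemical assay for solubility (a lower number here means a less soluble compound, a higher number a more soluble compound), compound 1 `Cn1nccc1-c1cc(C(F)(F)F)ccc1[C@H]1CCOc2cc(S(=O)(=O)Nc3nccs3)ccc21` gives 83000 nM and stands between compound 2 `Cn1nccc1-c1cc(C(F)(F)F)ccc1[C@H]1CCOc2cc(S(=O)(=O)Nc3ccc(F)cn3)ccc21` at 29000 nM and compound 3 `Cn1nccc1-c1cc(C(F)(F)F)ccc1[C@H]1CCOc2cc(S(=O)(=O)Nc3ccncn3)ccc21` at 1180000 nM on this scale. Compound 4 `O=S(=O)(Nc1nccs1)c1ccc2c(c1)OCC[C@@H]2c1ccc(C(F)(F)F)cc1-n1ccnn1` differs from compound 1 by one swap on an aromatic carbon (1H-1,2,3-triazol-1-yl in place of 1-methyl-1H-pyrazol-5-yl on an aromatic carbon), with the group on the sulfonamide nitrogen unchanged. The measured changes all sit on that nitrogen instead, giving a modest step (a 2.9-fold lower number from compound 1 to compound 2 (0.46 log units; beyond the scatter)) and large ones (a 14-fold higher number from compound 1 to compound 3 (1.15 log units; beyond the scatter) and a 41-fold higher number from compound 2 to compound 3 (1.61 log units; beyond the scatter)). Numbers in this assay can therefore move widely in this series, but none of these steps touches the swapped position or offers a direction. The estimate is a 1.2-fold higher number from compound 1 to compound 4 (0.08 log units; within the scatter) and so an expected step within the scatter. Compound 4 is expected at 100000 nM with an estimated range from 30000 nM to 350000 nM in this measurement.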

Compound 4, solubility: 171000 nM
Beside the measured number, compound 4's estimate is 1.7-fold (0.23 log units) below it, and the stated range covers the measured number.
By their numbers in this assay, from the lowest: compound 2; then compound 1; then compound 4; then compound 3.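

In this assay, this is the only step shown away from the sulfonamide nitrogen, and it shows that the aromatic carbon ortho to a large group also affects the read-out: a 2.1-fold higher number from compound 1 to compound 4 (0.31 log units; beyond the scatter). The step is modest, and the swap changes both the ring and its hetero atoms, with 1-methyl-1H-pyrazol-5-yl leaving and 1H-1,2,3-triazol-1-yl entering. No evidence here explains the shift.

A single step cannot separate the loss of the methyl from the added ring nitrogen. Also open, as far as these compounds go, are how an unmethylated pyrazole or a nitrile would read at this position, and whether the step holds with pyrimidin-4-yl on the sulfonamide nitrogen.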